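The compounds below may be only part of what the source reports. "The series", "measured", "known", "first", "only" and "open" are said of these compounds alone.

Compound 2 `O=C(O)[C@H]1CCC(=O)N1Cc1ccc(Cl)cc1` carries a carboxy group on its core, and in an assay on isolated protein for inhibition of matrix metalloproteinase-9 (Homo sapiens), read by fluorescence, with stated times of 1 h and 30 min (on this read-out higher numbers stand for weaker inhibition and lower numbers for stronger inhibition), compound 2 gives "not determined" (no result reported), so no number places it. Among the other entries, compound 1 `O=C(NO)[C@@H]1CCC(=O)N1Cc1ccccc1Cl` gives "not determined" (no result reported) in this assay. Compound 3 `O=C(NO)[C@@H]1CSCN1S(=O)(=O)c1ccc2ccccc2c1` reaches only a limit of the assay, > 50000 nM, which is the one numeric reading shown (the limit of > 50000 nM in this assay, at which 1 of the 3 values shown sits). Compound 2 therefore stands beside one limit and one further entry without a number, with no single value of its own.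

Compound 4 `O=C(NO)[C@H]1CCC(=O)N1Cc1ccc(Cl)cc1` differs from compound 2 by hydroxyamino in place of hydroxy on a carbonyl carbon. Among the measured compounds shown here, no measured pair shows this change in this assay, so the expected step has no measured size here. The step from carboxy to hydroxycarbamoyl is expected to move toward stronger inhibition, by more than the usual scatter, though without a measured anchor the estimate is wide. Compound 4 is expected to give about 40000 nM, between 5000 nM and 200000 nM, with a fair chance that only a limit is reported.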

Compound 4, half-maximal inhibitory concentration: 430000 nM
The estimate for compound 4 lay 11-fold (1.03 log units) below the measured number; measured number outside the range, above it.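

In this assay, among the compounds shown here, compound 4 gives 430000 nM, while compound 2 gives "not determined" (no result reported), so no step between these two compounds can be read. The compounds shown leave open how far hydroxycarbamoyl in place of carboxy shifts inhibition in this assay.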